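Inverting both stereocentres of compound 2

A few compounds are considered here, and "the series" means these few. Any claim that something is new, unique, unknown or untested is made for them only; others in the source may bear on it.

In an ADME assay on the whole organism (Rattus norvegicus) for metabolic stability, at a dose of 1 mg/kg by the intravenous route (a higher number here means faster removal of the compound, a lower number slower removal), compound 1 `COc1ccc(F)cc1-c1ccnc2[nH]c(C3=CCC(C(=O)O)CC3)cc12` gives 0.00517 mL/min/kg and compound 2 `COc1ccc(F)cc1-c1c(F)cnc2[nH]c(C3=CCN([C@H]4CC[C@@H](C(=O)O)CC4)CC3)cc12` gives 0.0157 mL/min/kg as the higher of the two numbers, a gap beyond the scatter. Compound 3 `COc1ccc(F)cc1-c1c(F)cnc2[nH]c(C3=CCN([C@H]4CC[C@H](C(=O)O)CC4)CC3)cc12` comes from compound 2 through a single change (the two compounds have the same atoms and bonds and differ only in configuration as drawn: 2 of 2 stereo elements differ (all stereocentres are inverted: mirror images); a stereocentre at a saturated ring carbon is drawn s in compound 2 and r in compound 3; a stereocentre at a saturated ring carbon is drawn s in compound 2 and r in compound 3) at the saturated ring carbons, leaving atoms and bonds the same. Among the measured compounds shown here, no measured pair shows what such a change does, so no step beyond the scatter is expected in either direction. The expected step (a 1.1-fold higher number from compound 2 to compound 3 (0.06 log units; within the scatter)) is therefore small. Compound 3 is estimated at 0.018 mL/min/kg with an expected range from 0.006 mL/min/kg to 0.06 mL/min/kg on this measure.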

Compound 3, clearance: 0.0105 mL/min/kg
Beside the measured number, compound 3's estimate is 1.7-fold (0.23 log units) above it, within the range that was stated.
By their numbers in this assay, from the lowest: compound 1; then compounds 3 and 2 (each within the scatter of the next).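

Inverting both stereocentres at the saturated ring carbons gives the only pair shown that reads configuration alone, and in this assay the result is a 1.5-fold lower number from compound 2 to compound 3 (0.17 log units; within the scatter). At this position, the two drawn configurations are therefore not told apart by this measure, something compounds 1 and 2 could not show. The comparison carries no other difference: the fact that compounds 2 and 3 differ only in the configuration as drawn

From the compounds shown here alone, whether this holds for other groups remains open: a primary amide or a nitrile in place of the carboxylic acid might separate the two configurations in this assay, or might not.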